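Swapping methyl for chloro on a quaternary ammonium naphthyridinone

The source may hold more compounds than are shown below. What is called first, only, known or untested is meant among the compounds shown, and "the series" means these compounds.

Measured compounds:
compound 1 `Cc1cc(OCCCCCCC[N+]23CCN(CC2)CC3)ccc1-n1cc(C(=O)Nc2cc(F)cc(F)c2)c(=O)c2ccc(N(C)C)nc21`: "not active" (no number reported)
compound 2 `CN(C)c1ccc2c(=O)c(C(=O)Nc3cc(F)cc(F)c3)cn(-c3ccc(OCCCCCCC[N+]45CCN(CC4)CC5)cc3Cl)c2n1`: 80%
compound 3 `Cc1cc(OCCCCCCC[N+]2(C)CCCC2)ccc1-n1cc(C(=O)Nc2cc(F)cc(F)c2)c(=O)c2ccc(N(C)C)nc21`: "not active" (no number reported)

Three compounds share one core and differ in two places: the small group on the aromatic ring that carries the long ether chain, and the charged ring at the end of that chain. In an assay on LX2 cells for inhibition of COL1A1 promoter (Homo sapiens), read by a luciferase reporter, with a stated time of 24 h, tested at 50 uM (on this read-out higher numbers stand for a stronger effect at the one concentration tested and lower numbers for a weaker effect), compound 3 reports no number, only the statement that it is not active, so it stands without a measurable value. Compound 1 sits in the same position, also without a number. Compound 2, which carries chloro rather than methyl on that ring, is the only one of the three with a reported figure in this assay.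

Compound 4 `CN(C)c1ccc2c(=O)c(C(=O)Nc3cc(F)cc(F)c3)cn(-c3ccc(OCCCCCCC[N+]4(C)CCCC4)cc3Cl)c2n1` is compound 3 with one change: chloro in place of methyl on an aromatic carbon. Within the data shown here, no measured pair shows this exact exchange, so its size is unknown. Among the measured compounds shown here, still, the two methyl compounds gave no number and the one chloro compound did, which suggests a step upward beyond the scatter, though one pair is thin evidence. Compound 4 is expected to give 55% in this assay, with a range from 10% to 90%.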

Compound 4, a percentage reported as inhibition, at one concentration (the size of the read-out at that concentration, not a potency): "not active" (no number reported)
Nothing numeric was reported for compound 4; there is nothing to compare the estimate with.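

In this assay compound 3 gives "not active" (no number reported) and compound 4 gives "not active" (no number reported), so no step can be read between them, and no supporting measurement bears on this result. The compounds shown leave open how much the charged ring at the chain's end matters, as it is the one place where compound 4 differs from compound 2, at 80%.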